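Aryl swap on the amide benzoyl: compound 3 to compound 4

The compounds below may be only part of what the source reports. "The series", "measured", "known", "first", "only" and "open" are said of these compounds alone.

Compound 1 `CC(C)N(Cc1cccc(OCCCCCC(=O)O)c1)C(=O)c1ccc(-c2ccoc2)cc1`, compound 2 `Cc1nnc(-c2cccc(-c3ccc(C(=O)N(Cc4cccc(OCCCCCC(=O)O)c4)C(C)C)cc3)c2)o1` and compound 3 `CCOC(=O)CCCCCOc1cccc(CN(C(=O)c2ccc(-c3ccoc3)cc2)C(C)C)c1` make up the measured set. In an ADME assay on HepG2 cells (Homo sapiens) for cytotoxicity, read by CellTiter-Glo and resazurin assay, with a stated time of 72 h (a higher number here means that more compound is needed for the effect, a lower number that less compound is needed), compound 1 gives only a limit, > 26000 nM. In this assay compound 2 likewise gives a limit, > 26000 nM. In this assay compound 3 also gives a limit, > 26000 nM. Compound 3 thus stands where every other measured value stands: the limit of > 26000 nM in this assay, at which 3 of the 3 values shown sit. The two steps that link the set, a step that the two limits leave unreadable from compound 1 to compound 2 and a step that the two limits leave unreadable from compound 1 to compound 3, have no readable size.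

Compound 4 `CCOC(=O)CCCCCOc1cccc(CN(C(=O)c2ccc(-c3cccc(C(F)(F)F)c3)cc2)C(C)C)c1` is not yet measured. Against compound 3 it differs as follows: 3-(trifluoromethyl)phenyl in place of furan-3-yl on an aromatic carbon. Neither measured step bears on this change in a readable way, and no value in the set departs from the limit. For compound 4 in this assay the expected result is around 30000 nM, with the range 12000 nM to 80000 nM. The step this estimate means, a step that the limit leaves unreadable from compound 3 to compound 4, is expected to be none beyond the scatter.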

Compound 4, half-maximal effective concentration: > 26000 nM
Compound 4 gave a limit, no number (the forecaster's own chance of this, stated with the estimate: 80%); the middle value does not contradict the limit.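

In this assay no step can be read from compound 3 to compound 4, since each gives only a limit and no number: the limit of > 26000 nM in this assay, at which 4 of the 4 values shown sit. The compounds shown leave open whether any of compounds 1 to 4 has a measurable half-maximal effective concentration in this assay at all.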